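A few compounds are considered here, and "the series" means these few. Any claim that something is new, unique, unknown or untested is made for them only; others in the source may bear on it.

In an assay on isolated protein for inhibition of DNA topoisomerase 1 (Homo sapiens), with a stated time of 30 min, tested at 100 uM (on this read-out lower numbers stand for a weaker effect and higher numbers for a stronger effect at the one concentration tested), compound 3 `Oc1cccc(-c2cc(-c3ccccc3)nc(-c3ccsc3)c2)c1` gives 6.9%, the lowest of the three numbers recorded. Compound 1 `Oc1ccc(-c2cc(-c3ccccc3)cc(-c3ccco3)n2)cc1` gives 18.6% in this assay, and compound 2 `Oc1ccc(-c2cc(-c3ccccc3)cc(-c3cccnc3)n2)cc1` gives 44%, so compound 3 sits beyond the scatter below both of them.

Compound 4 `Oc1cccc(-c2cc(-c3ccccc3)nc(-c3cccnc3)c2)c1` has not yet been measured. It differs from compound 3 in one place: pyridin-3-yl in place of thiophen-3-yl on an aromatic carbon. Within the data shown here, the only measured step that resembles this one is the change from compound 1 to compound 2, where pyridin-3-yl also entered on an aromatic carbon, though there it replaced furan-2-yl rather than thiophen-3-yl; that step was a number 25.4 percentage points higher from compound 1 to compound 2 (beyond the scatter). Because that step was a number 25.4 percentage points higher from compound 1 to compound 2 (beyond the scatter), a rise beyond the scatter for compound 4 is expected, although the group that leaves is not the same and the shared core carries a 3-hydroxyphenyl group rather than a 4-hydroxyphenyl group, so the size is uncertain. The expected step is a number 21.1 percentage points higher from compound 3 to compound 4 (beyond the scatter). Compound 4 is therefore estimated to give 28% in this assay, within a range from 10% to 50%.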

Compound 4, a percentage reported as inhibition, at one concentration (the size of the read-out at that concentration, not a potency): 8.1%
Compound 4: middle estimate off by 19.9 percentage points, on the high side, and the stated range ends above it.
By their numbers in this assay, from the lowest: compounds 3 and 4 (each within the scatter of the next); then compound 1; then compound 2.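

In this assay, pyridin-3-yl in place of thiophen-3-yl on this aromatic carbon, next to the ring nitrogen, gives a number 1.2 percentage points higher from compound 3 to compound 4 (within the scatter), whereas the earlier entry of the same group gave a number 25.4 percentage points higher from compound 1 to compound 2 (beyond the scatter). The rise seen earlier therefore does not follow from pyridin-3-yl alone: it appears in the pair where furan-2-yl leaves, on a core with a 4-hydroxyphenyl group, and not in this pair, where thiophen-3-yl leaves, on a core with a 3-hydroxyphenyl group. Nothing measured here accounts for the difference between the two steps.

The compounds shown leave open whether the leaving group or the core decides the size of the step. They also leave open how an amine or a carboxylic acid on this aromatic carbon would read in this assay.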